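A few compounds are considered here, and "the series" means these few. Any claim that something is new, unique, unknown or untested is made for them only; others in the source may bear on it.

Of the compounds shown here, three sharing one core have been measured, and compound 2 is the point of departure for the next one. Compound 1 `CCOc1cc(C)c(Cl)c2c1C(=O)C=CC2=O` gives 44200 nM in a functional assay on SNO cells (Homo sapiens) for cytotoxicity, read by XTT assay, with a stated time of 24 h; on this read-out higher numbers stand for weaker inhibition and lower numbers for stronger inhibition. Compound 2 `Cc1cc(O)c2c(c1Cl)C(=O)C=CC2=O` gives 17200 nM in this assay. Compound 3 `CC(=O)Oc1cc(OC(C)=O)c2c(OC(C)=O)c(C)cc(Cl)c2c1OC(C)=O` gives 53500 nM in this assay. Compound 2 thus stands lowest of the three numbers, with compound 1 nearest to it and compound 3 furthest, both separated from it by more than the scatter.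

Among the measured compounds shown here, only one step between measured compounds differs in a single place: a 2.6-fold lower number from compound 1 to compound 2 (0.41 log units; beyond the scatter), a modest move that concerns an oxygen substituent and not the halogen.

Compound 4 `Cc1cc(O)c2c(c1Br)C(=O)C=CC2=O` differs from compound 2 by bromo in place of chloro on an aromatic carbon. For the measured compounds named here, no measured step touches this position or this kind of exchange, so nothing among the three compounds bears directly on it. Going by the values given here, with no step to lean on, the expectation is a change in this assay of no more than the scatter in either direction, and the estimated step is a 1.1-fold lower number from compound 2 to compound 4 (0.06 log units; within the scatter). Compound 4 is therefore expected to give about 15000 nM in this assay, most likely between 6000 nM and 40000 nM.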

Compound 4, half-maximal inhibitory concentration: 14900 nM
For compound 4 the middle estimate is 1.0-fold (0.00 log units) above the measured one, within the range that was stated.
By their numbers in this assay, from the lowest: compounds 4 and 2 (each within the scatter of the next); then compounds 1 and 3 (each within the scatter of the next).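

Placing bromo in place of chloro on this aromatic carbon, which is para to a hydroxy group and ortho to a methyl group, gives a 1.2-fold lower number from compound 2 to compound 4 (0.06 log units; within the scatter) in this assay, so the first direct test of this position finds no difference between the two halogens that rises above the scatter. The only earlier single-place step, a 2.6-fold lower number from compound 1 to compound 2 (0.41 log units; beyond the scatter), concerned an oxygen substituent and lay beyond the scatter, so among these compounds that oxygen exchange shifts the number while this halogen exchange does not. Nothing measured alongside these compounds offers an explanation for how little this exchange alters the number.

The compounds shown carry only chloro or bromo at this position, so it remains open what fluoro, iodo, an amine or a carboxylic acid on this carbon would do to the number. As far as these compounds go, it also remains open whether bromo in place of chloro would be equally silent with the ethoxy group of compound 1 or the acetoxy groups of compound 3 in place of the hydroxy group of compound 2.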